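Cyclising the charged head group of compound 2

The source may report more compounds than this note shows. Statements on the series, on what has been measured and on what is new or still open speak of the compounds shown alone.

Compound 2 `CC[N+](C)(CC)CC(=O)N1N=C(C)CC1c1ccccc1OC` gives 4170 nM in a functional assay on PC-3 cells (Homo sapiens) for cytotoxicity, read by MTT assay, with a stated time of 48 h (a higher number here means a weaker inhibitor, a lower number a stronger inhibitor), the lowest of the two numbers at hand; compound 1 `COc1ccccc1C1CC(C)=NN1C(=O)CN1CCC(OC)CC1` gives 27200 nM. Compound 3 `COc1ccccc1C1CC(C)=NN1C(=O)C[N+]1(C)CCCC1` carries a group of 6 heavy atoms (5 carbon, 1 nitrogen; one five-membered non-aromatic ring with 1 hetero atom) in place of a group of 6 heavy atoms (5 carbon, 1 nitrogen; no ring), on a saturated chain carbon bound to a carbonyl carbon. Going by the values given here, the only measured step, a 6.5-fold lower number from compound 1 to compound 2 (0.81 log units; beyond the scatter), exchanged a neutral ring for a charged chain at this place, so it bears on compound 3 only loosely; no measured pair separates a charged chain from a charged ring. Compound 3 is therefore expected to stay close to compound 2, with a 1.1-fold higher number from compound 2 to compound 3 (0.03 log units; within the scatter) inside the scatter. The estimate for compound 3 is 4500 nM, between 1500 nM and 14000 nM.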

Compound 3, half-maximal inhibitory concentration: 11200 nM
Compound 3: middle estimate off by 2.5-fold (0.40 log units), on the low side; the measured number falls inside the stated range.
By their numbers in this assay, from the lowest: compound 2; then compound 3; then compound 1.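

In this assay, closing the charged chain into a five-membered non-aromatic ring is not a silent change at this place: a 2.7-fold higher number from compound 2 to compound 3 (0.43 log units; beyond the scatter), although both groups carry net charge +1. The ring still keeps an advantage over the group of compound 1, with a 2.4-fold lower number from compound 1 to compound 3 (0.39 log units; beyond the scatter), so part of the gain seen with the open chain survives cyclisation. Nothing on hand accounts for these differences. Open, on these data alone, is whether a six-membered piperidinium ring would fall nearer compound 2 or compound 3, and how a neutral diethylamino group would compare with the charged open chain.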